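The source may report more compounds than this note shows. Statements on the series, on what has been measured and on what is new or still open speak of the compounds shown alone.

Compound 1 `CNC(=O)/C=C1\CCc2c(C)cc(F)cc21` has been tested in a functional assay on the whole organism with Rattus norvegicus as the target, with a stated time of 3 h, at a dose of 20 mg/kg by the oral route (on this read-out lower numbers stand for less inhibition and higher numbers for more inhibition at the one dose given (going by the name of the read-out)), where compound 1 gives 40%. Among the measured compounds shown here, the only other measured compound, compound 2 `NC(=O)/C=C1\CCc2c(F)cc(Cl)cc21`, gives 36% in this assay, a number within the scatter of that of compound 1, so the two cannot be told apart. Compound 3 `Cc1cc(F)cc2c1CC/C2=C\C(=O)NC1CC1` has not yet been measured. It differs from compound 1 by cyclopropyl in place of methyl on an amide-type nitrogen. For the measured compounds named here, no measured pair shows this kind of change, so there is no step to lean on. The step from compound 1 to compound 3 is expected to be no change at the digits printed from compound 1 to compound 3 (within the scatter), none beyond the scatter. Compound 3 is therefore estimated at 40%, between 20% and 60%.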

Compound 3, a percentage reported as inhibition, in the whole organism at one dose (the size of the read-out at that dose, not a potency): 7%
Compound 3: middle estimate off by 33 percentage points, on the high side; the whole stated range lies above it.
By their numbers in this assay, from the lowest: compound 3; then compounds 2 and 1 (each within the scatter of the next).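

Cyclopropyl in place of methyl on an amide-type nitrogen gives a number 33 percentage points lower from compound 1 to compound 3 (beyond the scatter) in this assay. The read-out therefore responds strongly to this one substituent, which compounds 1 and 2, differing in more than one place, could not show. Nothing measured here gives a reason for this step.

As far as these compounds go, it remains open whether ethyl, isopropyl or a longer chain on this nitrogen would read like methyl or like cyclopropyl. From the compounds shown here alone, it is also open whether the same change would have a similar effect on a different core.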